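A few compounds are considered here, and "the series" means these few. Any claim that something is new, unique, unknown or untested is made for them only; others in the source may bear on it.

In a functional assay on CHO cells for antagonist activity at corticotropin-releasing factor receptor 1 (Homo sapiens), read by cAMP accumulation (a higher number here means a weaker inhibitor, a lower number a stronger inhibitor), two compounds have been measured so far:

Compound 1 `COc1ccc(-n2c(C)nc3c(NC(C4CC4)C4CC4)nc(C)nc32)cc1` gives 19 nM.
Compound 2 `Cc1nc(NC(C2CC2)C2CC2)c2nc(C)n(-c3ccc(F)cc3)c2n1` gives 91 nM.

Going by the values given here, compound 2 thus has the higher of the two numbers, and the only measured step, a 4.8-fold higher number from compound 1 to compound 2 (0.68 log units; beyond the scatter), separates it from compound 1; that step exchanged a methoxy group for a fluoro group on the aromatic carbon.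

Compound 3 `Cc1nc(NC(C2CC2)C2CC2)c2nc(C)n(-c3ccc(OC(F)(F)F)cc3)c2n1` is the next compound on this path. It differs from compound 2 by trifluoromethoxy in place of fluoro on an aromatic carbon. Among the compounds with values here, no measured pair shows exactly this exchange, so the step from compound 1 to compound 2 is the only one that bears on it, and only indirectly: it shows that, at this aromatic carbon, the oxygen-bearing group of compound 1 gave a lower number than the fluoro of compound 2. The trifluoromethoxy group of compound 3 restores an oxygen-bearing group at that carbon, so a move back toward the number of compound 1 is expected, but with caution, since the incoming group is not the methoxy of compound 1.

For compound 3 the expected step is a 2.3-fold lower number from compound 2 to compound 3 (0.36 log units; beyond the scatter), a lower number than compound 2. The estimate for compound 3 in this assay is 40 nM, with a range from 12 nM to 130 nM.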

Compound 3, inhibition constant: 9 nM
Compound 3: middle estimate off by 4.4-fold (0.65 log units), on the high side; the whole stated range lies above it.
By their numbers in this assay, from the lowest: compound 3; then compound 1; then compound 2.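

In this assay, the exchange on this aromatic carbon, para to a large group, gives a 10-fold lower number from compound 2 to compound 3 (1.00 log units; beyond the scatter) and is the largest step among the three compounds. The trifluoromethoxy group therefore does more than recover what was lost with fluoro, since replacing methyl with trifluoromethyl on the oxygen gives a 2.1-fold lower number from compound 1 to compound 3 (0.32 log units; beyond the scatter) and shows that the fluorines on that oxygen-bound carbon do not raise the number relative to the methoxy group; compound 3 has the lowest number, with its steps to both other compounds beyond the scatter. Nothing available here accounts for the order of trifluoromethoxy, methoxy and fluoro at this carbon.

The compounds shown leave open whether a group with no oxygen, such as trifluoromethyl or chlorine, would give a number closer to that of fluoro or to that of trifluoromethoxy, and whether a longer chain on the oxygen, such as ethoxy, would lower the number further. They also leave open whether the same order would hold if the dicyclopropylmethyl group on the amine nitrogen were replaced by another alkyl group.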